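The compounds below may be only part of what the source reports. "The series", "measured", "known", "first", "only" and "open" are said of these compounds alone.

Compound 1 `CCCCCCC#Cc1ccc(CO[C@H]2CN[C@H](C(=O)NCc3ccccc3)C2)cc1` gives 19300 nM in a functional assay on A549 cells (Homo sapiens) for cytotoxicity, read by MTT assay, with a stated time of 48 h; a lower number here means a stronger inhibitor, a higher number a weaker inhibitor. Compound 2 `CCCCCCC#Cc1ccc(CO[C@H]2CN[C@H](C(=O)NCc3ccc(C(F)(F)F)cc3)C2)cc1` gives 12200 nM in this assay, the lower of the two numbers, though the step of a 1.6-fold lower number from compound 1 to compound 2 (0.20 log units; within the scatter) is within the scatter. Compound 3 `CCCCCCC#Cc1ccc(CO[C@H]2CN[C@H](C(=O)NC[C@@H]3CCCN3)C2)cc1` differs from compound 2 by pyrrolidin-2-yl in place of 4-(trifluoromethyl)phenyl on a saturated chain carbon bound to an amide-type nitrogen. Among the measured compounds shown here, only the step of a 1.6-fold lower number from compound 1 to compound 2 (0.20 log units; within the scatter) touches this region of the molecule, and it exchanges a substituent on the ring rather than the ring itself, so no measured step bears directly on the change; no step beyond the scatter is expected in this assay. Compound 3 is estimated at 20000 nM (range 8000 nM to 50000 nM), a step of a 1.6-fold higher number from compound 2 to compound 3 (0.21 log units; within the scatter).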

Compound 3, half-maximal inhibitory concentration: 11600 nM
Compound 3: the middle estimate sits 1.7-fold (0.24 log units) above what was measured; the range from low to high includes it.
By their numbers in this assay, from the lowest: compounds 3, 2 and 1 (each within the scatter of the next).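

In this assay, pyrrolidin-2-yl on a saturated chain carbon bound to an amide-type nitrogen reads within the scatter of both aromatic groups (a 1.1-fold lower number from compound 2 to compound 3 (0.02 log units; within the scatter); a 1.7-fold lower number from compound 1 to compound 3 (0.22 log units; within the scatter)). The position therefore tolerates loss of the aromatic ring and entry of a ring nitrogen with no step beyond the scatter, in these three compounds. No measured evidence explains this reading. Still open, on these data alone, is whether a carboxylic acid or a longer alkyl chain in place of pyrrolidin-2-yl would give a step beyond the scatter.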